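From 4-fluorophenyl to 2-methylphenyl

The source may hold more compounds than are shown below. What is called first, only, known or untested is meant among the compounds shown, and "the series" means these compounds.

In a functional assay on KB cells (Homo sapiens) for cytotoxicity (on this read-out higher numbers stand for an effect only at larger amounts of compound and lower numbers for an effect already at smaller amounts), compound 1 `COC1=C(C)C(=O)/C(=C(O)/C=C/c2ccc(Br)cc2)C(=O)C1(C)C` gives 1.9 ug/mL and compound 2 `COC1=C(C)C(=O)/C(=C(O)/C=C/c2ccc(F)cc2)C(=O)C1(C)C` gives 2.7 ug/mL. Only these two numbers are available so far, and compound 2 stands within the scatter of compound 1. Compound 3 `COC1=C(C)C(=O)/C(=C(O)/C=C/c2ccccc2C)C(=O)C1(C)C` keeps the shared core but carries a different aryl group: 2-methylphenyl in place of 4-fluorophenyl on a double-bonded chain carbon bound to a double-bonded chain carbon. Among the compounds with values here, one measured step bears on this change, the exchange of bromo for fluoro a 1.4-fold higher number from compound 1 to compound 2 (0.15 log units; within the scatter), which stayed within the scatter. That step involves no methyl group and leaves the substituent where it was, so it is only a weak guide, and the range must stay wide. No step beyond the scatter is expected in this assay. The expected step is a 1.1-fold lower number from compound 2 to compound 3 (0.03 log units; within the scatter). The estimate for compound 3 is 2.5 ug/mL, with an expected range from 1 ug/mL to 6 ug/mL.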

Compound 3, concentration for half-maximal effect: 1.6 ug/mL
For compound 3 the middle estimate is 1.6-fold (0.19 log units) above the measured one; low and high end bracket the measured number.
By their numbers in this assay, from the lowest: compounds 3, 1 and 2 (each within the scatter of the next).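

In this assay, 2-methylphenyl in place of 4-fluorophenyl gives a 1.7-fold lower number from compound 2 to compound 3 (0.23 log units; within the scatter), and 2-methylphenyl in place of 4-bromophenyl gives a 1.2-fold lower number from compound 1 to compound 3 (0.07 log units; within the scatter). The earlier pair only exchanged one halogen for another, whereas this change removes the halogen altogether and brings in a methyl group, and the number on this read-out still stays within the scatter on both steps. Nothing at hand gives a reason for this result.

All three aryl groups on this double-bonded chain carbon are phenyl rings without hydrogen-bond donors or acceptors, so the compounds shown leave open what an amine or a carboxylic acid on the ring would do. They also leave open whether any exchange at this place can move the number beyond the scatter in this assay.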